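Trading a Nitrophenyl for a Dichlorophenyl

The source may hold more compounds than are shown below. What is called first, only, known or untested is meant among the compounds shown, and "the series" means these compounds.

In a functional assay on HL-60 cells (Homo sapiens) for inhibition, read by CCK-8 assay, with a stated time of 48 h (a higher number here means a weaker inhibitor, a lower number a stronger inhibitor), compound 2 `COc1cccc(NC(=O)NCCNS(=O)(=O)c2ccc(-c3ccccc3OCc3ccccc3)s2)c1` gives 1700 nM, and compound 3 `O=C(NCCNS(=O)(=O)c1ccc(-c2ccccc2OCc2ccccc2)s1)Nc1cccc([N+](=O)[O-])c1` gives 2800 nM. These two values sit within the scatter of each other, as the step shows: a 1.6-fold higher number from compound 2 to compound 3 (0.22 log units; within the scatter). Compound 1 `O=S(=O)(NCCNC(=S)Nc1cccc(Cl)c1)c1ccc(-c2ccccc2OCc2ccccc2)s1` gives > 50000 nM, which is a limit and not a number.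

Compound 4 `O=C(NCCNS(=O)(=O)c1ccc(-c2ccccc2OCc2ccccc2)s1)Nc1cc(Cl)cc(Cl)c1` differs from compound 3 at one place, with 3,5-dichlorophenyl in place of 3-nitrophenyl on an amide-type nitrogen.

The closest guide is the exchange of methoxy for nitro between compound 2 and compound 3, which changes a group on the same ring and leaves no step beyond the scatter. The large steps, an at least 29-fold lower number from compound 1 to compound 2 (1.46 log units; beyond the scatter) and an at least 17-fold lower number from compound 1 to compound 3 (1.25 log units; beyond the scatter), help less: the group replaced there also holds sulfur, so they do not isolate a ring substituent.

The expected step is small: a 1.6-fold lower number from compound 3 to compound 4 (0.19 log units; within the scatter). For compound 4 the estimated value is 1800 nM, with an expected range from 600 nM to 6000 nM.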

Compound 4, half-maximal inhibitory concentration: 11700 nM
Compound 4: the middle estimate sits 6.5-fold (0.81 log units) below what was measured; measured number above the stated range.
By their numbers in this assay, from the lowest: compounds 2 and 3 (each within the scatter of the next); then compound 4. At a limit, above all of these: compound 1.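

In this assay the ring on the amide-type nitrogen proves sensitive to what it carries: methoxy and nitro stayed within the scatter of each other, yet 3,5-dichlorophenyl gives a 4.2-fold higher number from compound 3 to compound 4 (0.62 log units; beyond the scatter) and also a 6.9-fold higher number from compound 2 to compound 4 (0.84 log units; beyond the scatter) with both steps beyond the scatter. The weakening still has a visible bound, with an at least 4.2-fold lower number from compound 1 to compound 4 (0.63 log units; beyond the scatter) in the comparison with the group that holds sulfur, although that step changes more than the ring substituents. Compound 1 is held at a limit and not a number: the limit of > 50000 nM in this assay, at which 1 of the 4 values shown sits.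

This change removes one group and brings in two chlorines at once, so the compounds shown cannot separate the effect of chlorine itself from the number of groups on the ring. As far as these compounds go, how an amine or a carboxylic acid on this ring would read in this assay also stays open.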